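The source may hold more compounds than are shown below. What is called first, only, known or untested is meant among the compounds shown, and "the series" means these compounds.

Compound 1 `c1ccc(-c2nn(-c3ccccc3)c3nccc(-c4cccs4)c23)cc1`: 39300 nM
Compound 2 `CN1CCN(c2ccc(-c3c(C#N)c(-c4ccc(Cl)cc4)nc4c3c(-c3ccccc3)nn4-c3ccccc3)cc2)CC1`: 14600 nM

In a functional assay on HepG2 cells (Homo sapiens) for inhibition, read by MTT assay, with a stated time of 48 h (a higher number here means a weaker inhibitor, a lower number a stronger inhibitor), compound 1 gives 39300 nM, the higher of the two numbers and so the weaker inhibitor of the pair. Compound 2, which differs from it in more than one place, stands lower at 14600 nM, a gap beyond the usual scatter.

Compound 3 `Fc1ccc(-c2ccnc3c2c(-c2ccccc2)nn3-c2ccccc2)cc1` has not yet been measured in this assay. It keeps the core of compound 1 and carries 4-fluorophenyl in place of thiophen-2-yl on an aromatic carbon, opposite the ring nitrogen: 4-fluorophenyl in place of thiophen-2-yl on an aromatic carbon.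

Among the compounds with values here, no two measured compounds differ in one place only, so the data offer no direct guide to this exchange of one aromatic ring for another. Within the data shown here, the only hint is that compound 2, with far more altered, still reaches just 14600 nM. A small change is therefore expected, slightly towards a lower number and not clearly beyond the scatter: the estimated step is a 1.3-fold lower number from compound 1 to compound 3 (0.12 log units; within the scatter). For compound 3 the expected value is 30000 nM, with an estimated range from 12000 nM to 70000 nM.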

Compound 3, half-maximal inhibitory concentration: 1570 nM
Compound 3: middle estimate off by 19-fold (1.28 log units), on the high side, and the stated range ends above it.
By their numbers in this assay, from the lowest: compound 3; then compound 2; then compound 1.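

In this assay, within the data shown here, the exchange of thiophen-2-yl for 4-fluorophenyl on the aromatic carbon opposite the ring nitrogen gives a 25-fold lower number from compound 1 to compound 3 (1.40 log units; beyond the scatter), and this is the first reading of a single change. It shows that this position is not indifferent to which aromatic ring it carries: with the rest of the core of compound 1 unchanged, one ring in place of another moves the number well beyond the scatter, which compound 2, differing from compound 1 in more than one place, could not show. The exchange replaces a five-membered aromatic ring with 1 hetero atom by a six-membered aromatic ring of carbon only and brings in fluorine at the same time, and no measurement at hand gives a reason for the step.

The compounds shown leave open whether the step belongs to the six-membered ring or to its fluorine, which an unsubstituted phenyl, a 4-methoxyphenyl or a pyridine ring at this carbon would help to separate. They also leave open whether the exchange would give a step of similar size on a core that carries the nitrile and 4-chlorophenyl groups of compound 2.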